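A few compounds are considered here, and "the series" means these few. Any claim that something is new, unique, unknown or untested is made for them only; others in the source may bear on it.

In an ADME assay on RAW264.7 cells (Mus musculus) for cytotoxicity, read by neutral red uptake, with a stated time of 24 h (a higher number here means that more compound is tolerated, a lower number that less compound is tolerated), three compounds had been tested, and none returned a number. Compound 1 `O=C(CN1C(=O)CSC1=O)NOCc1ccccc1` gave > 128000 nM, which is a limit of the assay. Compound 2 `C=CCONC(=O)C(C)N1C(=O)CSC1=O` gave > 128000 nM, again a limit. Compound 3 `O=C(CN1C(=O)S/C(=C\c2ccccc2)C1=O)NOCc1ccccc1` gave > 128000 nM, also a limit. Compound 3 therefore has no rank among the three, and the record so far comes down to the limit of > 128000 nM in this assay, at which 3 of the 3 values shown sit.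

Compound 4 `C=CCONC(=O)CN1C(=O)S/C(=C\c2ccccc2)C1=O` had yet to be measured. It departs from compound 3 in one place: vinyl in place of phenyl on a saturated chain carbon bound to an oxygen. This puts vinyl in place of phenyl on a saturated chain carbon bound to an oxygen, so that benzyloxy becomes allyloxy. Going by the values given here, no measured pair of compounds differs in one place, so the size of this change cannot be read directly from the data. Compound 2 also carries allyloxy, and its > 128000 nM is likewise a limit. On that basis, no change beyond the usual scatter is expected in this assay, in either direction. The estimated step of a number no higher from compound 3 to compound 4 (the limit leaves the size open) lies within that scatter. For compound 4 the expected value is 128000 nM, with an estimated range of 64000 nM to 256000 nM, and the result may well be reported only as a limit.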

Compound 4, half-maximal cytotoxic concentration: > 128000 nM
Compound 4: no number, only a limit; the forecaster's own chance of this, stated with the estimate: 80%; the middle value lies on the limit itself.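

In this assay compound 4 gave > 128000 nM, which is a limit and not a number. Compound 3 also stands at a limit, so no step can be read between compound 3 and compound 4. The compounds shown leave open what concentration, if any, would reach the half-maximal cytotoxic effect for any of them, and the record remains: the limit of > 128000 nM in this assay, at which 4 of the 4 values shown sit.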